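The compounds below may be only part of what the source reports. "The series", "measured", "known", "first", "only" and "open" are said of these compounds alone.

Compound 3 `O=C(Nc1ccc(Sc2nc3ccccc3s2)c(Cl)c1)c1ccccc1` is the starting point of this step. In an assay for inhibition of HSP60/HSP10 (Homo sapiens), with a stated time of 60 min (a lower number here means a stronger inhibitor, a higher number a weaker inhibitor), compound 3 gives > 100000 nM, which is a limit of the assay and not a number. Compound 2 `O=C(Nc1ccc(Sc2nc3ccccc3s2)c(Cl)c1)c1cccc(Br)c1` differs from compound 3 by a bromo group on an aromatic carbon, and in this assay compound 2 gives > 100000 nM, again a limit. The step that the two limits leave unreadable from compound 2 to compound 3 therefore cannot be read, since (the limit of > 100000 nM in this assay, at which 3 of the 3 values shown sit).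

Compound 4 `COc1ccc(Br)cc1C(=O)Nc1ccc(Sc2nc3ccccc3s2)c(Cl)c1` carries 5-bromo-2-methoxyphenyl in place of phenyl on a carbonyl carbon. Within the data shown here, no measured step covers this change directly. Compound 1 `COc1ccc(Br)cc1C(=O)Nc1ccc(Sc2nc3ccccc3s2)cc1` has the same 5-bromo-2-methoxyphenyl on the carbonyl carbon, but without the chloro on the shared core, and in this assay compound 1 gives > 100000 nM, a limit. Among the measured compounds shown here, every value so far sits at the same limit, so nothing points toward a gain. Compound 4 is therefore expected to remain at the limit, with an estimated value around 150000 nM ranging from 30000 nM to 1000000 nM, which means an expected step that the limit leaves unreadable from compound 3 to compound 4 that cannot be resolved beyond the scatter.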

Compound 4, half-maximal inhibitory concentration: > 100000 nM
Compound 4 ended at the assay's limit; the forecaster's own chance of this, stated with the estimate: 85%; the middle value does not contradict the limit.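

In this assay, among these compounds, compound 4 also sits at a limit, so no step from compound 1, compound 2 or compound 3 to compound 4 can be read: the limit of > 100000 nM in this assay, at which 4 of the 4 values shown sit. The compounds shown leave open whether any change on this shared core gives a readable inhibition at all.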